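Tolerated Concentration Across Four Related Compounds

This account rests on a few compounds, and the source may have more. Where it says the series, first, only, none or still open, it means among the compounds named here.

Compound 1 `Cc1cc(-c2ccc(F)cc2)cc(C)c1Oc1cc(N)nc(Nc2ccc(C#N)cc2)n1` gives 23100 nM in a toxicity assay on MT4 cells (Homo sapiens) for cytotoxicity, read by MTT assay; a higher number here means that more compound is tolerated, a lower number that less compound is tolerated. Compound 2 `Cc1cc(-c2cccc(Cl)c2)cc(C)c1Oc1cc(N)nc(Nc2ccc(C#N)cc2)n1` gives 22300 nM in this assay. Compound 3 `COc1ccc(-c2cc(C)c(Oc3cc(N)nc(Nc4ccc(C#N)cc4)n3)c(C)c2)cc1` gives 10700 nM in this assay.

Compound 1 stands highest of the three numbers. Its nearest neighbour is compound 2: a 1.0-fold lower number from compound 1 to compound 2 (0.02 log units; within the scatter). Its furthest is compound 3: a 2.2-fold lower number from compound 1 to compound 3 (0.33 log units; beyond the scatter). Compound 3 also sits below compound 2: a 2.1-fold lower number from compound 2 to compound 3 (0.32 log units; beyond the scatter). Compound 4 `Cc1cc(-c2ccccc2C#N)cc(C)c1Oc1cc(N)nc(Nc2ccc(C#N)cc2)n1` has not yet been measured in this assay. Relative to compound 1 the change is 2-cyanophenyl in place of 4-fluorophenyl on an aromatic carbon. All three measured steps bear on it, since each exchanges the group on that same aromatic carbon: the exchange from compound 1 to compound 2 stayed within the scatter, while the two steps leading to compound 3 were modest lowerings. For compound 4 a step of at most modest size is therefore expected, most likely within the scatter, with a slight lean downward: a 1.3-fold lower number from compound 1 to compound 4 (0.11 log units; within the scatter). Compound 4 is estimated at 18000 nM, within a range of 8000 nM to 40000 nM.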

Compound 4, half-maximal cytotoxic concentration: 25400 nM
The estimate for compound 4 lay 1.4-fold (0.15 log units) below the measured number, within the range that was stated.
By their numbers in this assay, from the lowest: compound 3; then compounds 2, 1 and 4 (each within the scatter of the next).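

Exchanging 4-fluorophenyl for 2-cyanophenyl on this aromatic carbon in this assay brings in a nitrile and a hydrogen-bond acceptor, yet the two numbers stay within the scatter of each other (a 1.1-fold higher number from compound 1 to compound 4 (0.04 log units; within the scatter)). The 3-chlorophenyl group of compound 2 likewise stays within the scatter of 2-cyanophenyl (a 1.1-fold higher number from compound 2 to compound 4 (0.06 log units; within the scatter)), whereas the 4-methoxyphenyl group stands apart (a 2.4-fold higher number from compound 3 to compound 4 (0.38 log units; beyond the scatter)), so among these four compounds only compound 3 separates from the rest. Nothing at hand gives a measured explanation for that separation.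

The compounds shown leave open how a carboxylic acid or a basic amine on this phenyl ring would read in this assay. They also leave open whether a 2-methoxyphenyl group would stand with compound 3 or with the other three compounds.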